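The source may report more compounds than this note shows. Statements on the series, on what has been measured and on what is new or still open speak of the compounds shown alone.

Compound 1, `O=C(CN(c1nc(Cl)nc2[nH]cnc12)C1CC1)N[C@@H](CO)C(=O)OCc1ccccc1`, gives 34.5% in a functional assay on the whole organism (Tail, strain ICR) with Mus musculus as the target, in the tail flick test, with a stated time of 90 min, at a dose of 25 umol/kg by the oral route; on this read-out lower numbers stand for a weaker effect and higher numbers for a stronger effect at the one dose given. Compound 2, `NC(=O)CC[C@H](NC(=O)CN(c1ncnc2c1ncn2C1CCCCO1)C1CC1)C(=O)OCc1ccccc1`, gives 37.8% in the same test. Compound 3, `N=C(N)NCCC[C@H](NC(=O)CN(c1nc(Cl)nc2[nH]cnc12)C1CC1)C(=O)O`, gives 27.6%.

Among these three numbers compound 1 falls between the other two: compound 2 sits a few points higher and compound 3 a few points lower, and both gaps lie within the usual scatter of repeated measurements. The three compounds therefore cannot be told apart on the numbers shown, and no measured pair differs in a single place, so no step of known size is available as a guide.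

Compound 4, `CC(C)[C@H](NC(=O)CN(c1nc(Cl)nc2[nH]cnc12)C1CC1)C(=O)OCc1ccccc1`, has not yet been measured. It differs from compound 1 in one place: isopropyl in place of hydroxymethyl on a saturated chain carbon bound to an amide-type nitrogen and a carbonyl carbon. The rest of the molecule, the shared core and the benzyl ester, is kept. Among the compounds with values here, with no single-point step among the measured compounds to lean on, and with all three measured values lying within the scatter of one another, the step from compound 1 to compound 4 is expected to be small, in no clear direction, and not beyond the scatter, as a number 0.5 percentage points higher from compound 1 to compound 4 (within the scatter) expresses. Compound 4 is accordingly estimated at 35%, with a range from 20% to 50%.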

Compound 4, a percentage reported as activity, at one dose (the size of the read-out at that dose, not a potency): 51.3%
Compound 4: middle estimate off by 16.3 percentage points, on the low side, and the stated range ends below it.
By their numbers in this assay, from the lowest: compounds 3, 1 and 2 (each within the scatter of the next, the first and the last beyond it); then compound 4.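

In this assay, within the data shown here, isopropyl in place of hydroxymethyl on a saturated chain carbon bound to an amide-type nitrogen and a carbonyl carbon gives a number 16.8 percentage points higher from compound 1 to compound 4 (beyond the scatter) and so provides the only single-place step in this set. Among these compounds, it shows that, with the shared core and the benzyl ester kept, this position can shift the read-out at the one dose and time tested, which the three earlier compounds could not show, since they stood within or near the scatter of one another and no pair differed in one place. The change swaps a group with a hydrogen-bond donor and acceptor for one with neither, but no measurement on hand gives a reason for the step.

The compounds shown leave open whether the step follows the loss of the hydroxyl or the gain in carbon, a question that a plain methyl, a longer chain such as isobutyl, or an amine at this position would help to settle. They also leave open whether the same change would carry over to a carboxylic acid in place of the benzyl ester, and whether the effect would hold at other doses.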